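The source may report more compounds than this note shows. Statements on the series, on what has been measured and on what is new or still open speak of the compounds shown alone.

Working notes on the series. Compound 1 `COc1cc(-c2nnc(SCc3ccc(C)cc3)o2)ccc1O` gives 6210 nM in a functional assay on cells (T-cell, Mus musculus, strain BALB/c) for inhibition, read by MTT assay, with stated times of 24 h and 72 h; a higher number here means a weaker inhibitor, a lower number a stronger inhibitor. Compound 2 `COc1cc(-c2nnc(SCc3ccccc3Br)o2)ccc1O` gives 17800 nM in this assay, and compound 3 `COc1cc(-c2nnc(SCc3ccc(F)cc3)o2)ccc1O` gives 8190 nM. Compound 3 thus sits second highest of the three numbers: a 1.3-fold higher number from compound 1 to compound 3 (0.12 log units; within the scatter) stays within the scatter, whereas a 2.2-fold lower number from compound 2 to compound 3 (0.34 log units; beyond the scatter) marks the one separation beyond the scatter, as does a 2.9-fold higher number from compound 1 to compound 2 (0.46 log units; beyond the scatter).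

The next compound, compound 4 `COc1cc(-c2nnc(SCc3ccc(Br)cc3)o2)ccc1O`, differs from compound 3 by bromo in place of fluoro on an aromatic carbon. The change sits on an aromatic carbon of a six-membered aromatic ring of carbon only, para to a large group, the same site at which compound 1 carries methyl and compound 3 carries fluoro. The step that bears on it most directly is a 1.3-fold higher number from compound 1 to compound 3 (0.12 log units; within the scatter), which stayed within the scatter; the exchanges involving compound 2 moved the ring substituent to a different position and are less informative here. On this basis the step is expected to be a 1.0-fold lower number from compound 3 to compound 4 (0.01 log units; within the scatter), no shift beyond the scatter in either direction.

Compound 4 is therefore estimated at 8000 nM in this assay, with a range of 4000 nM to 16000 nM.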

Compound 4, half-maximal inhibitory concentration: 8830 nM
The estimate for compound 4 lay 1.1-fold (0.04 log units) below the measured number; the measured number falls inside the stated range.
By their numbers in this assay, from the lowest: compounds 1, 3, 4 and 2 (each within the scatter of the next, the first and the last beyond it).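

At the aromatic carbon para to a large group, bromo now joins methyl and fluoro with no separation in this assay: a 1.1-fold higher number from compound 3 to compound 4 (0.03 log units; within the scatter) and a 1.4-fold higher number from compound 1 to compound 4 (0.15 log units; within the scatter) both stay within the scatter, so these three groups cannot be told apart at this site. Going by these compounds alone, the new compound also gives the first comparison with the halogen held constant, and a 2.0-fold lower number from compound 2 to compound 4 (0.30 log units; within the scatter) lies within the scatter as well, so compound 2 stands beyond the scatter from compound 1 and compound 3 but not from compound 4, and the effect of bromine placement alone is not resolved. No supporting data bear on why the numbers at this site stay so close.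

Whether the site stays this flat for a different kind of group, such as a carboxylic acid or a dimethylamino group, remains open, since the three groups shown there are only methyl, fluoro and bromo. Also open, on these data alone, is whether a second pair differing only in ring placement, such as 2-fluorophenyl against 4-fluorophenyl, would separate beyond the scatter.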